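From Two Hydroxy Groups to One

The source may report more compounds than this note shows. Statements on the series, on what has been measured and on what is new or still open speak of the compounds shown alone.

The account concerns two measured compounds in an assay on membranes from brain for displacement of a labelled ligand from adenosine receptor A1 (Rattus norvegicus), read by radioligand binding; a higher number here means a weaker inhibitor, a lower number a stronger inhibitor. Compound 1 `COc1cccc2c1C/C(=C\c1ccc(N(C)C)cc1)C2=O` gives in this assay only a limit, > 100000 nM, and no number. Compound 2 `COc1cccc2c1C/C(=C\c1ccc(O)c(O)c1)C2=O` gives in this assay 42 nM. Compound 2 therefore stands as the only number shown. The other value shown is the limit of > 100000 nM in this assay, at which 1 of the 2 values shown sits, and it belongs to compound 1. Among the measured compounds shown here, no step between two measured compounds that differ in one place is available.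

Compound 3 `COc1cccc2c1C/C(=C\c1ccc(O)cc1)C2=O` has not yet been measured. It differs from compound 2 by hydrogen in place of hydroxy on an aromatic carbon. Without a measured step of this kind to rest on, the expectation is drawn from the structural change alone. The step from compound 2 to compound 3 is expected to go toward weaker binding in this assay, beyond the usual scatter, estimated as a 7.1-fold higher number from compound 2 to compound 3 (0.85 log units; beyond the scatter). Compound 3 is expected to give about 300 nM, with a range from 60 nM to 3000 nM.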

Compound 3, inhibition constant: > 100000 nM
Compound 3 ended at the assay's limit; the forecaster's own chance of this, stated with the estimate: 5%; middle value at least 330-fold (2.52 log units) away from the limit.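

In this assay compound 3 gives > 100000 nM, which is a limit of the assay and not a number. Hydrogen in place of the hydroxy that stands ortho to a hydroxy group gives an at least 2300-fold higher number from compound 2 to compound 3 (3.37 log units; beyond the scatter), so for this pair the first measured step shows that this one position decides between measurable binding and none within the assay's range, and that the remaining hydroxy alone does not preserve it. Most of the compounds now sit at the same ceiling: the limit of > 100000 nM in this assay, at which 2 of the 3 values shown sit.

The step between compound 1 and compound 3 cannot be read, with a limit on both sides. Still open, going by these compounds, is what the second hydroxy of compound 2 contributes, and whether a methoxy, a fluorine or an amine at this position would retain any of the binding of compound 2.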